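This account rests on a few compounds, and the source may have more. Where it says the series, first, only, none or still open, it means among the compounds named here.

Compound 1 `CC(C)[C@H](NC(=O)COc1cccc2ccccc12)C(=O)N[C@@H](CC(=O)O)C(=O)COC(=O)c1c(Cl)cccc1Cl` anchors the set, and in a functional assay on Jurkat cells (Homo sapiens) (a lower number here means a stronger inhibitor, a higher number a weaker inhibitor), compound 1 gives 10600 nM. Compound 2 `CC(=O)Nc1cccc(OCC(=O)[C@H](CC(=O)O)NC(=O)[C@@H](NC(=O)COc2cccc3ccccc23)C(C)C)c1` carries a 3-acetamidophenyl in place of the (2,6-dichlorophenyl)carbonyl on an oxygen on a saturated carbon. In this assay compound 2 reaches only a limit of the assay, > 100000 nM, so its place among the numbers shown is the limit itself rather than a value. Compound 3 `CC(C)[C@H](NC(=O)COc1cccc2ccccc12)C(=O)N[C@@H](CC(=O)O)C(=O)COc1cc(F)cc(F)c1`, with 3,5-difluorophenyl on an oxygen on a saturated carbon, likewise gives in this assay a limit, > 100000 nM. The two changes away from compound 1 were an at least 9.4-fold higher number from compound 1 to compound 2 (0.97 log units; beyond the scatter) and an at least 9.4-fold higher number from compound 1 to compound 3 (0.97 log units; beyond the scatter); the step between the two phenyl variants is a step that the two limits leave unreadable from compound 2 to compound 3, because both sit at the limit of > 100000 nM in this assay, at which 2 of the 3 values shown sit.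

Compound 4 `CC(C)[C@H](NC(=O)COc1cccc2ccccc12)C(=O)N[C@@H](CC(=O)O)C(=O)COc1cccc(C(F)(F)F)c1F` differs from compound 2 by 2-fluoro-3-(trifluoromethyl)phenyl in place of 3-acetamidophenyl on an oxygen on a saturated carbon. Going by the values given here, the steps that bear on this are the two from compound 1, both at least modest losses once a phenyl group replaced the (2,6-dichlorophenyl)carbonyl, and the unreadable one between compound 2 and compound 3. Nothing shown separates one phenyl variant from another. The expected step is therefore a number no higher from compound 2 to compound 4 (the limit leaves the size open), none beyond the scatter, with compound 4 expected to stay at or near the limit. Compound 4 is estimated at 100000 nM, in a range from 30000 nM to 300000 nM.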

Compound 4, half-maximal inhibitory concentration: 50400 nM
The estimate for compound 4 lay 2.0-fold (0.30 log units) above the measured number; the range from low to high includes it.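

In this assay, a phenyl group on an oxygen on a saturated carbon no longer gives only a limit: 2-fluoro-3-(trifluoromethyl)phenyl is the one phenyl variant shown to return a measured number. The steps read an at least 1.9-fold lower number from compound 2 to compound 4 (0.29 log units; that floor lies within the scatter) and an at least 1.9-fold lower number from compound 3 to compound 4 (0.29 log units; that floor lies within the scatter), so the phenyl variants may differ after all, yet neither floor goes beyond the scatter, and the true size of either step stays hidden because compound 2 and compound 3 give only limits: the limit of > 100000 nM in this assay, at which 2 of the 4 values shown sit. The step of a 4.8-fold higher number from compound 1 to compound 4 (0.68 log units; beyond the scatter) shows that this change of (2,6-dichlorophenyl)carbonyl for a phenyl group still costs activity, but that the loss need not carry a compound to the limit.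

The fluorine and the trifluoromethyl enter together in compound 4, so the compounds shown do not tell which of them, if either, accounts for its measurable number. Also open, from the compounds shown here alone, is how a 2,6-dichlorophenyl on the same oxygen, without the carbonyl, would read, which would separate the loss of the carbonyl from the change of substituents on the ring.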